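The source may report more compounds than this note shows. Statements on the series, on what has been measured and on what is new or still open speak of the compounds shown alone.

Measured so far in a physicochemical assay for lipophilicity, read by HPLC, at pH 7.4; on this read-out higher numbers stand for higher lipophilicity and lower numbers for lower lipophilicity:
compound 1 `Cc1cc(OCc2cccc3nccn23)cc(C)c1-c1cccc(COc2ccc3c(c2)OC[C@H]3CC(=O)O)c1`: 3.8
compound 2 `Cc1nc(C)c(COc2cc(C)c(-c3cccc(COc4ccc5c(c4)OC[C@H]5CC(=O)O)c3)c(C)c2)s1`: 4.27

Compound 2 stands highest of the two, and its gap to compound 1 lies beyond the usual scatter. Compound 3 `Cc1cc(OCC2(O)CCS(=O)(=O)CC2)cc(C)c1-c1cccc(COc2ccc3c(c2)OC[C@H]3CC(=O)O)c1` has not yet been measured. It keeps the shared core and changes one group: 4-hydroxy-1,1-dioxothian-4-yl in place of 2,4-dimethyl-1,3-thiazol-5-yl on a saturated chain carbon bound to an oxygen on an aromatic ring. Here 4-hydroxy-1,1-dioxothian-4-yl takes the place of 2,4-dimethyl-1,3-thiazol-5-yl on a saturated chain carbon bound to an oxygen on an aromatic ring.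

Within the data shown here, only one measured step bears on this place, a number 0.47 log units higher from compound 1 to compound 2 (beyond the scatter), and it was modest. Both groups in that step hold a five-membered aromatic ring, whereas the entering group here holds no aromatic ring, so that step is only a weak guide. A clearly larger move downward in this assay is expected. The expected change is a number 1.67 log units lower from compound 2 to compound 3 (beyond the scatter). Compound 3 is estimated at 2.6, with a range of 2.1 to 3.1.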

Compound 3, distribution coefficient: 2.43
Compound 3: middle estimate off by 0.17 log units, on the high side; measured number inside the range.
By their numbers in this assay, from the lowest: compound 3; then compound 1; then compound 2.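

In this assay, among these compounds, 4-hydroxy-1,1-dioxothian-4-yl in place of 2,4-dimethyl-1,3-thiazol-5-yl on this saturated chain carbon gives a number 1.84 log units lower from compound 2 to compound 3 (beyond the scatter), a far larger move than the only earlier step at this place, a number 0.47 log units higher from compound 1 to compound 2 (beyond the scatter). The same entering group also gives a number 1.37 log units lower from compound 1 to compound 3 (beyond the scatter), so the fall appears from both aromatic starting groups, and this position spans a wide range of values on this read-out, with compound 3 the lowest of the three. No measurement is available that would explain the size of this change.

The entering group differs from both earlier groups in its ring, its hydroxy group and its two oxygens on sulfur all at once, so the compounds shown do not separate the share of each. Going by these compounds, how a simple thian-4-yl ring, a 4-hydroxycyclohexyl ring or an amine would read at this place remains open.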